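Hydrazone series: thiadiazolyl to phenyltetrazolyl thioether swap

This account rests on a few compounds, and the source may have more. Where it says the series, first, only, none or still open, it means among the compounds named here.

Measured compounds:
Compound 1 `Cc1nnc(SCC(=O)N/N=c2/scc(-c3ccccc3)n2-c2ccccc2)s1` gives 72.4% in a functional assay on C6 cells (Rattus norvegicus) for cytotoxicity, read by MTT assay, with a stated time of 24 h, tested at 6 ug/mL; on this read-out lower numbers stand for a stronger effect and higher numbers for a weaker effect at the one concentration tested.
Compound 2 `COc1ccc(-c2cs/c(=N/NC(=O)CSc3nnc(C)s3)n2-c2ccccc2)cc1` gives 57.9% in this assay.
Compound 3 `Cn1nnnc1SCC(=O)N/N=c1/scc(-c2ccc([N+](=O)[O-])cc2)n1-c1ccccc1` gives 80.4% in this assay.

Compound 1 stands second highest of the three numbers; compound 3 lies nearest, within the scatter, while compound 2 lies furthest, beyond the scatter. Among the measured compounds shown here, the single one-place step known is a number 14.5 percentage points lower from compound 1 to compound 2 (beyond the scatter), which concerns the aryl ring and not the thioether end of the chain.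

Compound 4 `O=C(CSc1nnnn1-c1ccccc1)N/N=c1/scc(-c2ccccc2)n1-c1ccccc1` is unmeasured. Its change from compound 1 is 1-phenyl-1H-tetrazol-5-yl in place of 5-methyl-1,3,4-thiadiazol-2-yl on a sulfur. For the measured compounds named here, no measured step touches this position in one place. Compound 3 carries a different tetrazolyl group on that sulfur together with a nitro group, and its value sits within the scatter of compound 1, so the two values show no separation. Going by the values given here, with no step bearing directly on the change, the expectation is a step of a number 0.4 percentage points lower from compound 1 to compound 4 (within the scatter), that is none beyond the scatter, in this assay.

Compound 4 is therefore estimated at 72%, with a range from 55% to 88%.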

Compound 4, a percentage reported as activity, at one concentration (the size of the read-out at that concentration, not a potency): 52.1%
Compound 4: the middle estimate sits 19.9 percentage points above what was measured; measured number outside the range, below it.
By their numbers in this assay, from the lowest: compounds 4 and 2 (each within the scatter of the next); then compounds 1 and 3 (each within the scatter of the next).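

The thioether end of the chain proves responsive in this assay: replacing 5-methyl-1,3,4-thiadiazol-2-yl with 1-phenyl-1H-tetrazol-5-yl on the sulfur gives a number 20.3 percentage points lower from compound 1 to compound 4 (beyond the scatter). Among the compounds shown here, this is the first one-place step at this position, so the group on the sulfur can no longer be treated as neutral in this assay on the evidence of compound 3, which differs from compound 1 in more than one place. The entering group brings 11 heavy atoms against 6 and adds a six-membered aromatic ring of carbon only, but no measurement on hand explains the step.

The step does not separate the change of five-membered ring from the added phenyl, and 5-phenyl-1,3,4-thiadiazol-2-yl on the same sulfur would address that question. As far as these compounds go, whether the step carries over to the core of compound 2 also remains open.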